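The source may hold more compounds than are shown below. What is called first, only, known or untested is meant among the compounds shown, and "the series" means these compounds.

Four esters share one core and differ only in the chain on the ester. Compound 1 `CC(=O)Oc1c(C(C)C)cc2c3c1OC(=O)[C@@]31CCCC(C)(C)[C@@H]1CC2` carries the shortest chain, and in an ADME assay on AGS cells (Homo sapiens) for cytotoxicity, read by neutral red uptake, with a stated time of 24 h (a lower number here means a stronger inhibitor, a higher number a weaker inhibitor), compound 1 gives 275000 nM. Compound 2 `CCCC(=O)Oc1c(C(C)C)cc2c3c1OC(=O)[C@@]31CCCC(C)(C)[C@@H]1CC2` gives 99500 nM, the step being a 2.8-fold lower number from compound 1 to compound 2 (0.44 log units; beyond the scatter). Compound 3 `CCCCCCCCCCCCCCCC(=O)Oc1c(C(C)C)cc2c3c1OC(=O)[C@@]31CCCC(C)(C)[C@@H]1CC2` gives only a limit of the assay, > 1000000 nM. The next step is an at least 10-fold higher number from compound 2 to compound 3 (1.00 log units; beyond the scatter). Compound 4 `CCCCC/C=C/C/C=C/CCCCCCCC(=O)Oc1c(C(C)C)cc2c3c1OC(=O)[C@@]31CCCC(C)(C)[C@@H]1CC2` differs from compound 3 by deca-1,4-dien-1-yl in place of octyl on a saturated chain carbon, seven bonds along the chain from a carbonyl carbon. Only the long-chain step bears on this change, and it carried the number out of range; compound 4 keeps a chain of similar length, so no step beyond the scatter is expected, and the reading may again be a limit because the limit of > 1000000 nM in this assay, at which 1 of the 3 values shown sits, is where compound 3 sits. Compound 4 is expected to give 1000000 nM, between 300000 nM and 3000000 nM, an expected step of a number no higher from compound 3 to compound 4 (the limit leaves the size open).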

Compound 4, half-maximal inhibitory concentration: 253000 nM
Estimate against measurement, compound 4: 4.0-fold (0.60 log units) above; measured number outside the range, below it.
By their numbers in this assay, from the lowest: compound 2; then compounds 4 and 1 (each within the scatter of the next). At a limit, above all of these: compound 3.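

Replacing octyl with deca-1,4-dien-1-yl, on a saturated chain carbon seven bonds along the chain from a carbonyl carbon, gives an at least 3.9-fold lower number from compound 3 to compound 4 (0.59 log units; beyond the scatter). Compound 3 gives only a limit, > 1000000 nM. Compound 4 gives a measurable number despite its long chain, so at this position a long chain does not always bring the reading to the limit.

This change adds both carbons and double bonds, and the compounds shown do not separate the two. A saturated chain of the same length, or a chain with a single double bond, would test each part.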